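A Ring Swap on the Shared Core and Its Stability

The source may hold more compounds than are shown below. What is called first, only, known or untested is meant among the compounds shown, and "the series" means these compounds.

Three compounds share one core and differ only in the group attached to a saturated chain carbon bound to an aromatic carbon and a saturated chain carbon. Compound 1 `CC(C)NC(=O)CC(c1ccc(-c2ccc3cccc(F)c3c2)[nH]c1=O)C(C)C` carries (isopropylcarbamoyl)methyl there, compound 2 `CC(C)C(Nc1nccs1)c1ccc(-c2ccc3cccc(F)c3c2)[nH]c1=O` a (1,3-thiazol-2-yl)amino group, and compound 3 `CC(C)C(c1ccc(-c2ccc3cccc(F)c3c2)[nH]c1=O)N1CCNC1=O` a 2-oxoimidazolidin-1-yl group. In an ADME assay on microsomes from liver (Rattus norvegicus) for metabolic stability (on this read-out higher numbers stand for a longer-lived compound and lower numbers for a shorter-lived compound), compound 1 reaches only a limit of the assay, < 0.0667 h, as noted by the limit of < 0.0667 h in this assay, at which 1 of the 3 values shown sits. In this assay compound 2 gives 0.07 h, while compound 3 gives 0.283 h, the highest of the two real numbers. The steps are a 4.0-fold higher number from compound 2 to compound 3 (0.61 log units; beyond the scatter) and an at least 4.2-fold higher number from compound 1 to compound 3 (0.62 log units; beyond the scatter), whereas an at least 1.0-fold higher number from compound 1 to compound 2 (0.02 log units; that floor lies within the scatter).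

Compound 4 `CC(C)C(/C=C1\CCNC1=O)c1ccc(-c2ccc3cccc(F)c3c2)[nH]c1=O` changes the same group once more: a group of 7 heavy atoms (5 carbon, 1 nitrogen, 1 oxygen; one five-membered non-aromatic ring with 1 hetero atom) in place of a group of 6 heavy atoms (3 carbon, 2 nitrogen, 1 oxygen; one five-membered non-aromatic ring with 2 hetero atoms), on a saturated chain carbon bound to an aromatic carbon and a saturated chain carbon. The two steps leading into compound 3 bear on this change, since they show that the group at this position shifts the half-life by a modest amount. Within the data shown here, the entering group keeps one hydrogen-bond donor and one hydrogen-bond acceptor in a five-membered non-aromatic ring, but no measured pair shows what the extra double bond and the loss of a ring nitrogen do. Expected is a small downward step, a 1.9-fold lower number from compound 3 to compound 4 (0.28 log units; within the scatter), close to the scatter. Compound 4 is therefore estimated at 0.15 h, with a range from 0.05 h to 0.45 h.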

Compound 4, half-life: 0.345 h
For compound 4 the middle estimate is 2.3-fold (0.36 log units) below the measured one; the range from low to high includes it.
By their numbers in this assay, from the lowest: compound 2; then compounds 3 and 4 (each within the scatter of the next). At a limit, below all of these: compound 1.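

In this assay, the new group, with one ring nitrogen fewer and a second double bond outside aromatic rings, takes the place of 2-oxoimidazolidin-1-yl with a 1.2-fold higher number from compound 3 to compound 4 (0.09 log units; within the scatter), so this change gives no readable shift in half-life. Among these compounds, the gain over the (1,3-thiazol-2-yl)amino group is also not tied to one group alone, since a 4.9-fold higher number from compound 2 to compound 4 (0.69 log units; beyond the scatter) is a step of similar size to the one that led to compound 3, and compounds 3 and 4 both carry a five-membered non-aromatic ring at this place. The remaining comparison, an at least 5.1-fold higher number from compound 1 to compound 4 (0.71 log units; beyond the scatter), starts from a limit of the assay rather than a number: the limit of < 0.0667 h in this assay, at which 1 of the 4 values shown sits.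

The ring nitrogen and the double bond change together between compound 3 and compound 4, so neither can be judged alone. On these data alone, whether a six-membered ring, an open-chain urea or a simple amine on this saturated chain carbon would keep the half-life of compounds 3 and 4 stays open, as does which part of the five-membered rings matters.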